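The compounds below may be only part of what the source reports. "The series", "measured", "known", "first", "only" and "open" are said of these compounds alone.

Measured in an assay on isolated protein for displacement of a labelled ligand from Bcl2-associated agonist of cell death (Homo sapiens), read by fluorescence polarization; a higher number here means a weaker inhibitor, a lower number a stronger inhibitor:
compound 1 `CN(C)CC[C@H](CSc1ccccc1)Nc1ccc(S(=O)(=O)NC(=O)c2ccc(N3CCN(Cc4ccccc4-c4ccc(Cl)cc4)CC3)cc2)cc1OC(F)(F)F` gives < 1 nM
compound 2 `CN(C)CC[C@H](CSc1ccccc1)Nc1ccc(S(=O)(=O)NC(=O)c2ccc(N3CCN(CC4=C(c5ccc(Cl)cc5)CCC(C)(C)C4)CC3)cc2)cc1[N+](=O)[O-]` gives 1.4 nM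
compound 3 `CN(C)CC[C@H](CSc1ccccc1)Nc1ccc(S(=O)(=O)NC(=O)c2ccc(N3CCN(CC4=C(c5ccc(Cl)cc5)CCC4)CC3)cc2)cc1[N+](=O)[O-]` gives < 1 nM

The value for compound 1 is a limit of the assay, not a number. The value for compound 3 is likewise a limit. Among the compounds with values here, two of the three values thus sit at the limit of < 1 nM in this assay, at which 2 of the 3 values shown sit, and compound 2 carries the only number; no step between measured compounds can be set out, so the series gives no measured guide for a single change.

Compound 4 `Cc1cc(S(=O)(=O)NC(=O)c2ccc(N3CCN(Cc4ccccc4-c4ccc(Cl)cc4)CC3)cc2)ccc1N[C@H](CCN(C)C)CSc1ccccc1` remains to be measured in this assay. It differs from compound 1 in one place (methyl in place of trifluoromethoxy on an aromatic carbon). The step is expected to run toward weaker binding, beyond the scatter, at an at least 3.0-fold higher number from compound 1 to compound 4 (0.47 log units; beyond the scatter). Compound 4 is therefore expected to give about 3 nM, with a range from 1 nM to 15 nM.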

Compound 4, inhibition constant: < 1 nM
Compound 4: only a limit was reported (the forecaster's own chance of this, stated with the estimate: 25%); middle value at least 3.0-fold (0.47 log units) away from the limit.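

Compound 1 and compound 4 both sit at an assay limit in this assay, so no step can be read between them: the limit of < 1 nM in this assay, at which 3 of the 4 values shown sit. From the compounds shown here alone, whether methyl in place of trifluoromethoxy changes binding at all remains open.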